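Chalcone series on OVCAR-4: notes toward compound 3

The compounds below may be only part of what the source reports. "The series", "measured", "known", "first", "only" and "open" are said of these compounds alone.

Measured so far:
compound 1, `COc1cc(/C=C/C(=O)c2cccc(-n3cc(-c4ccc(Cl)cc4)[nH]c3=O)c2)cc(OC)c1OC`, 11400 nM
compound 2, `COc1cc(/C=C/C(=O)c2cccc(-n3cc(-c4ccccc4)[nH]c3=O)c2)ccc1O`, 5190 nM

The read-out is a functional assay on OVCAR-4 cells (Homo sapiens) for inhibition; a higher number here means a weaker inhibitor of growth, a lower number a stronger inhibitor of growth. On the numbers in hand, compound 2 holds the lowest value, and the gap from compound 2 to compound 1 is beyond the usual scatter, so compound 2 is the stronger growth inhibitor of the two. For the measured compounds named here, compound 1 and compound 2 differ in more than one place, so no single step between them can be read out.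

Compound 3, `O=C(/C=C/c1cccc(O)c1)c1cccc(-n2cc(-c3ccccc3)[nH]c2=O)c1`, is not yet measured. It differs from compound 2 by a single change, (3-hydroxyphenyl in place of 4-hydroxy-3-methoxyphenyl on a double-bonded chain carbon bound to a double-bonded chain carbon). Going by the values given here, no step of this kind is known, so the direction can only be guessed. The expectation is a small step from compound 2 to compound 3, about a 1.3-fold higher number from compound 2 to compound 3 (0.13 log units; within the scatter), towards a somewhat weaker inhibitor, with a real chance that the step stays within the scatter. For compound 3 the estimate in this assay is 7000 nM, with a range from 2500 nM to 20000 nM.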

Compound 3, concentration for 50% growth inhibition: 5300 nM
Estimate against measurement, compound 3: 1.3-fold (0.12 log units) above; the measured number falls inside the stated range.
By their numbers in this assay, from the lowest: compounds 2 and 3 (each within the scatter of the next); then compound 1.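

In this assay, 3-hydroxyphenyl in place of 4-hydroxy-3-methoxyphenyl on a double-bonded chain carbon bound to a double-bonded chain carbon gives a 1.0-fold higher number from compound 2 to compound 3 (0.01 log units; within the scatter) and so stays within the scatter. For the compounds shown here, this is the first single-place comparison, and it shows that, with the rest of compound 2 held fixed, the two aryl groups cannot be told apart in this read-out, although the entering group has 7 heavy atoms and 1 hydrogen-bond acceptor against 9 heavy atoms and 2 hydrogen-bond acceptors in the group that leaves. No measurement to hand accounts for this flat step, so it stands as an observation only.

As far as these compounds go, whether this position stays as flat with a group of another kind, such as an aminophenyl or a carboxyphenyl ring or an unsubstituted phenyl, remains open. The differences between compound 1 and the other two compounds span more than one place and cannot be read as steps, so the contribution of each place to that gap is also unresolved.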